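Moving a methoxy group on the ester aryl ring

The compounds below may be only part of what the source reports. "The series", "measured", "known", "first", "only" and "open" are said of these compounds alone.

Three compounds have been measured in a functional assay on Jurkat E6.1 cells (Homo sapiens) for cytotoxicity, read by MTT assay, with a stated time of 24 h; a lower number here means a stronger inhibitor, a higher number a weaker inhibitor:

compound 1, `COC(=O)/C(=C\c1ccc(O)cc1)Sc1ccnc2cc(Cl)ccc12`, gives 5180 nM
compound 2, `COC(=O)/C(=C\c1ccc(OC(=O)c2ccccc2)cc1)Sc1ccnc2cc(Cl)ccc12`, gives 35700 nM
compound 3, `COC(=O)/C(=C\c1ccc(OC(=O)c2cccc(OC)c2)cc1)Sc1ccnc2cc(Cl)ccc12`, gives 33300 nM

Compound 3 sits within the scatter of compound 2 and far from compound 1, which is the only one of the three that lies beyond the scatter of the others. The two ester-bearing compounds are separated from compound 1 by a 6.9-fold higher number from compound 1 to compound 2 (0.84 log units; beyond the scatter) and a 6.4-fold higher number from compound 1 to compound 3 (0.81 log units; beyond the scatter), both modest steps in the same direction, while adding the methoxy group gave a 1.1-fold lower number from compound 2 to compound 3 (0.03 log units; within the scatter), a step inside the scatter.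

Compound 4, `COC(=O)/C(=C\c1ccc(OC(=O)c2ccccc2OC)cc1)Sc1ccnc2cc(Cl)ccc12`, differs from compound 3 only in the change (2-methoxyphenyl in place of 3-methoxyphenyl on a carbonyl carbon). Among the compounds with values here, the one measured step that bears on this change, the step from compound 2 to compound 3, was within the scatter, so relocating the methoxy group on the same ring is expected to give a step of similar size, that is a 1.0-fold lower number from compound 3 to compound 4 (0.02 log units; within the scatter), with no direction beyond the scatter. Compound 4 is therefore estimated at 32000 nM, within a range of 15000 nM to 70000 nM.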

Compound 4, half-maximal inhibitory concentration: 44700 nM
The estimate for compound 4 lay 1.4-fold (0.15 log units) below the measured number, within the range that was stated.
By their numbers in this assay, from the lowest: compound 1; then compounds 3, 2 and 4 (each within the scatter of the next).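

In this assay, the change from 3-methoxyphenyl to 2-methoxyphenyl on the carbonyl carbon gave a 1.3-fold higher number from compound 3 to compound 4 (0.13 log units; within the scatter), and adding the methoxy group to compound 2 at this new place gave a 1.3-fold higher number from compound 2 to compound 4 (0.10 log units; within the scatter), so neither change of place nor presence of the methoxy group is resolved on this ring. The larger difference remains that between the hydrogen of compound 1 and the acyl group, now seen a third time as an 8.6-fold higher number from compound 1 to compound 4 (0.94 log units; beyond the scatter), and all three esters lie on the same side of compound 1. No measurement shown offers an explanation for these results.

Going by these compounds, it remains open whether 4-methoxyphenyl, or an amine or a carboxylic acid on this ring, would move beyond the scatter of compound 2. An amide in place of the ester is likewise untested among the compounds shown.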